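Furan substituent swap in the indanone series

This account rests on a few compounds, and the source may have more. Where it says the series, first, only, none or still open, it means among the compounds named here.

Within the data shown here, compound 1 `COc1ccc2c(c1)C/C(=C\c1ccc(Br)o1)C2=O` carries the only numbered value in the set: in an assay on isolated protein for inhibition of Amine oxidase [flavin-containing] B (Homo sapiens), read by fluorescence, with a stated time of 20 min (on this read-out lower numbers stand for stronger inhibition and higher numbers for weaker inhibition), compound 1 gives 4.4 nM. Compound 2 `O=C(/C=C/c1ccc(F)cc1)c1ccc2c(c1)OCCO2` gives < 100 nM in this assay, which is a limit of the assay and not a number. Compound 2 therefore sits at the limit of < 100 nM in this assay, at which 1 of the 2 values shown sits. No step between measured compounds is shown, so compound 1 stands alone on the numbers and no pattern can be drawn from the pair.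

Compound 3 `COc1ccc2c(c1)C/C(=C\c1ccc(C)o1)C2=O` is not yet measured. It differs from compound 1 by methyl in place of bromo on an aromatic carbon. Among the measured compounds shown here, with no measured step to lean on, the expectation for this assay is a modest weakening, within or slightly beyond the scatter rather than a large shift.

Compound 3 is expected to give 12 nM in this assay, with a range from 3 nM to 50 nM. The expected step is a 2.7-fold higher number from compound 1 to compound 3 (0.44 log units; beyond the scatter), a small loss.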

Compound 3, half-maximal inhibitory concentration: 26 nM
Estimate against measurement, compound 3: 2.2-fold (0.34 log units) below; low and high end bracket the measured number.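

Among these compounds, this is the first measured step: in this assay, going from 5-bromofuran-2-yl to 5-methylfuran-2-yl gives a 5.9-fold higher number from compound 1 to compound 3 (0.77 log units; beyond the scatter). The carbon next to the ring oxygen is therefore sensitive to what it carries: a swap of one heavy atom for one heavy atom, with no ring, hydrogen-bond donor, hydrogen-bond acceptor or net charge entering or leaving, moves the number beyond the scatter, yet compound 3 still gives 26 nM. No measured property at hand accounts for this step.

On these data alone, with only bromo and methyl compared at this place, it remains open how chloro, ethyl or an amine would read here. As far as these compounds go, whether bromo keeps its edge over methyl on any other core also remains open.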